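The compounds below may be only part of what the source reports. "The series", "measured", "known", "first", "only" and "open" are said of these compounds alone.

Values in a functional assay on MCF7 cells (Homo sapiens) for cytotoxicity, read by CellTiter-Glo, with a stated time of 5 days; on this read-out higher numbers stand for weaker inhibition and lower numbers for stronger inhibition:
- compound 1 `CC/C(=C(/c1ccc(/C=C/C(=O)O)cc1)c1ccc(NS(C)(=O)=O)cc1)c1ccccc1`: 2310 nM
- compound 2 `CC/C(=C(/c1ccc(/C=C/C(=O)O)cc1)c1ccc2[nH]c(=O)sc2c1)c1ccccc1`: 158 nM
- compound 3 `CC/C(=C(/c1ccc(/C=C/C(=O)O)cc1)c1ccc2[nH]ccc2c1)c1ccccc1`: 9 nM

Compound 3 has the lowest number of the three, at 9 nM. Compound 4 `CC/C(=C(/c1ccc(/C=C/C(=O)O)cc1)c1ccc2[nH]ncc2c1)c1ccccc1` carries 1H-indazol-5-yl in place of 1H-indol-5-yl on the same double-bonded chain carbon: 1H-indazol-5-yl in place of 1H-indol-5-yl on a double-bonded chain carbon bound to an aromatic carbon and a double-bonded chain carbon. For the measured compounds named here, only one measured step bears on this place, an 18-fold lower number from compound 2 to compound 3 (1.24 log units; beyond the scatter), and it is large, but it involves a different group and so offers only a loose guide. The entering group shares a five-membered aromatic ring with 2 hetero atoms with compound 2 at 158 nM, which leaves room on the higher side. The expected change in this assay is a 1.7-fold higher number from compound 3 to compound 4 (0.22 log units; within the scatter), so no step beyond the scatter is expected. For compound 4 the estimated value is 15 nM, with an expected range from 5 nM to 60 nM.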

Compound 4, half-maximal inhibitory concentration: 6 nM
For compound 4 the middle estimate is 2.5-fold (0.40 log units) above the measured one; the measured number falls inside the stated range.
By their numbers in this assay, from the lowest: compounds 4 and 3 (each within the scatter of the next); then compound 2; then compound 1.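

In this assay, 1H-indazol-5-yl and 1H-indol-5-yl cannot be told apart on this double-bonded chain carbon, with a 1.5-fold lower number from compound 3 to compound 4 (0.18 log units; within the scatter). Holding a five-membered aromatic ring with 2 hetero atoms therefore does not by itself set the number: a 26-fold lower number from compound 2 to compound 4 (1.42 log units; beyond the scatter), and both groups hold such a ring.

No measurement on hand accounts for the gap between these two groups. From the compounds shown here alone, how a plain phenyl or a simple amide would fare at this place, with no fused five-membered ring, remains open.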